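Pyrrolidin-1-yl in place of methylamino: notes on compound 4

The compounds below may be only part of what the source reports. "The series", "measured", "known", "first", "only" and "open" are said of these compounds alone.

In a functional assay on the whole organism with Rattus norvegicus as the target (on this read-out lower numbers stand for an effect already at smaller amounts and higher numbers for an effect only at larger amounts of compound), compound 2 (`CNc1cc(OC)c(C(=O)NC2CCN(Cc3ccccc3)C2)cc1Cl`) gives 0.016 mg/kg as the lowest of three numbers, beyond the scatter from both others. Compound 1 (`COc1ccc(OC)c(C(=O)NCCN(C)Cc2ccccc2)c1`) gives 3 mg/kg on this read-out and compound 3 (`CCN1CCC(NC(=O)c2cc(Cl)c(NC)cc2OC)C1`) gives 10 mg/kg on it.

Compound 4 (`COc1cc(N2CCCC2)c(Cl)cc1C(=O)NC1CCN(Cc2ccccc2)C1`) has pyrrolidin-1-yl in place of methylamino on an aromatic carbon, ortho to a chloro group: pyrrolidin-1-yl in place of methylamino on an aromatic carbon is the whole difference.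

Going by the values given here, the only measured step of a 630-fold higher number from compound 2 to compound 3 (2.80 log units; beyond the scatter) puts methyl in place of phenyl on a saturated chain carbon bound to an amine nitrogen in a ring. That step is large, but it lies elsewhere in the structure. Among the compounds with values here, no measured step touches the methylamino group, so the series gives no direct guide here. With compound 2 at 0.016 mg/kg as the low end of the series, a moderate move towards a higher number in this assay is expected, well short of that large step. The expected change is a 6.3-fold higher number from compound 2 to compound 4 (0.80 log units; beyond the scatter) with wide uncertainty. For compound 4 the estimate is 0.1 mg/kg with an expected range from 0.02 mg/kg to 0.6 mg/kg for a measured number.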

Compound 4, dose for half-maximal effect: 0.6 mg/kg
Compound 4: the middle estimate sits 6.0-fold (0.78 log units) below what was measured; the measured number falls inside the stated range.
By their numbers in this assay, from the lowest: compound 2; then compound 4; then compound 1; then compound 3.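

In this assay the aromatic carbon ortho to a chloro group proves to be a sensitive place: a 38-fold higher number from compound 2 to compound 4 (1.57 log units; beyond the scatter), so the series now holds a large step at this position as well as the one on the ring nitrogen, a 630-fold higher number from compound 2 to compound 3 (2.80 log units; beyond the scatter). The change is not a single one, since methylamino with 1 hydrogen-bond donor and 2 heavy atoms gives way to pyrrolidin-1-yl with 0 hydrogen-bond donors, 5 heavy atoms and a five-membered non-aromatic ring. Nothing to hand explains the size of this step.

The compounds shown leave open whether the higher number goes with the lost amine hydrogen or with the added ring. A dimethylamino group on this carbon would separate the two, and an unsubstituted amino group would show how far the methyl of compound 2 matters.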